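A few compounds are considered here, and "the series" means these few. Any claim that something is new, unique, unknown or untested is made for them only; others in the source may bear on it.

Compound 1 `OC[C@@]1(c2ccc(O)cc2)NC[C@@H](O)[C@@H]1O`: 11000 nM
Compound 2 `OC[C@@]1(c2c(F)c(F)c(F)c(F)c2F)NC[C@@H](O)[C@@H]1O`: 66000 nM

Among the measured compounds shown here, in an assay on isolated protein for inhibition of lysosomal alpha-glucosidase (Rattus norvegicus), read by colorimetric assay (a higher number here means a weaker inhibitor, a lower number a stronger inhibitor), compound 1 gives 11000 nM, the lower of the two numbers measured so far. Compound 2 gives 66000 nM in this assay, a gap beyond the usual scatter, so compound 1 is the stronger inhibitor of the pair. Compound 3 `Cc1ccc([C@]2(CO)NC[C@@H](O)[C@@H]2O)cc1` has not yet been measured. It departs from compound 1 in a single place: methyl in place of hydroxy on an aromatic carbon. For the measured compounds named here, no step between two measured compounds touches this position, so the size of such a change has no direct precedent here, and the one measured comparison concerns a different part of the ring. A step of moderate size toward a higher number in this assay is expected, although the data leave open the possibility of no change beyond the scatter. Compound 3 is estimated at 18000 nM, with a range from 6000 nM to 55000 nM, which means an expected step of a 1.6-fold higher number from compound 1 to compound 3 (0.21 log units; within the scatter).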

Compound 3, half-maximal inhibitory concentration: 43000 nM
The estimate for compound 3 lay 2.4-fold (0.38 log units) below the measured number; the range from low to high includes it.
By their numbers in this assay, from the lowest: compound 1; then compounds 3 and 2 (each within the scatter of the next).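

In this assay, methyl in place of hydroxy on this aromatic carbon gives a 3.9-fold higher number from compound 1 to compound 3 (0.59 log units; beyond the scatter), the first step read at a single place among these compounds, and it shows that inhibition depends on which of these two groups the position carries. Hydroxy, with 1 hydrogen-bond donor and 1 hydrogen-bond acceptor, leaves, and methyl, with 0 of each, enters, so this one step cannot separate the loss of hydroxy from the gain of methyl. No measurement at hand accounts for the size of this step.

The compounds shown leave open how an amine, a methoxy group or a carboxylic acid on this aromatic carbon would read, and whether a plain hydrogen there would fall nearer compound 1 or compound 3. They also leave open whether the same change would give a step of similar size elsewhere on the aromatic ring.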